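Trimming the hydrazide end of compound 1

The compounds below may be only part of what the source reports. "The series", "measured", "known", "first", "only" and "open" are said of these compounds alone.

Measured so far:
compound 1, `COc1cc(NC(C)CCCNC(=O)NNC(=O)N(CCO)CCO)c2ncccc2c1`: > 100000 nM
compound 2, `COc1cc(NC(C)CCCNC(=O)NNC(=O)Nc2ccc(Cl)c(C(F)(F)F)c2)c2ncccc2c1`: 13000 nM
compound 3, `COc1cc(NC(C)CCCNC(=O)NNC(=O)NCCCC(C)Nc2cc(OC)cc3cccnc23)c2ncccc2c1`: 94000 nM

In a functional assay on NCI-H460 cells (Homo sapiens) for inhibition, read by MTT assay, with a stated time of 4 days (a lower number here means a stronger inhibitor, a higher number a weaker inhibitor), compound 1 gives > 100000 nM, which is a limit of the assay and not a number (the limit of > 100000 nM in this assay, at which 1 of the 3 values shown sits). Compound 2 gives 13000 nM, and compound 3 gives 94000 nM. Within the data shown here, the one step measured between these compounds is an at least 7.6-fold lower number from compound 1 to compound 2 (0.88 log units; beyond the scatter). Compound 4, `COc1cc(NC(C)CCCNC(=O)NN)c2ncccc2c1`, differs from compound 1 by hydrogen in place of bis(2-hydroxyethyl)carbamoyl on an amine nitrogen. Among the measured compounds shown here, this change has no measured counterpart: the single measured step exchanges the group for another rather than removing it. Since compound 1 stands only at a limit, the expected step of a number no higher from compound 1 to compound 4 (the limit leaves the size open) is set at none beyond the scatter. Compound 4 is therefore expected to give about 100000 nM, in a range from 30000 nM to 300000 nM.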

Compound 4, half-maximal inhibitory concentration: > 100000 nM
Compound 4 ended at the assay's limit (the forecaster's own chance of this, stated with the estimate: 60%); the middle value sits exactly at the limit.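

Compound 1 and compound 4 each stand at a limit and not at a number, so no step can be read between them: the limit of > 100000 nM in this assay, at which 2 of the 4 values shown sit.

The compounds shown leave open whether hydrogen in place of bis(2-hydroxyethyl)carbamoyl changes the number at all.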